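This account rests on a few compounds, and the source may have more. Where it says the series, first, only, none or still open, it means among the compounds named here.

In a functional assay on NCI-H23 cells (Homo sapiens) for antiproliferative activity, read by MTT assay, with a stated time of 72 h (on this read-out higher numbers stand for weaker inhibition and lower numbers for stronger inhibition), compound 1 `C=CC(=O)Nc1cc(Nc2nccc(NC(=O)c3ccc(C(F)(F)F)cc3)n2)c(OC)cc1N1CCN(C)CC1` gives 9200 nM and compound 2 `C=CC(=O)Nc1cc(Nc2nccc(NC(=O)c3ccc(C(F)(F)F)cc3)n2)c(OC)cc1N(C)CCN(C)C` gives 7980 nM so the two stand level. For the measured compounds named here, the one measured step is a 1.2-fold lower number from compound 1 to compound 2 (0.06 log units; within the scatter) and it concerns (2-(dimethylamino)ethyl)(methyl)amino in place of 4-methylpiperazin-1-yl, not the group changed next. Going by the values given here, compound 3 `C=CC(=O)Nc1cc(Nc2nccc(NC(=O)c3ccccc3)n2)c(OC)cc1N1CCN(C)CC1` differs from compound 1 by hydrogen in place of trifluoromethyl on an aromatic carbon, a change that no measured step covers. In this assay the expected step is a 1.3-fold lower number from compound 1 to compound 3 (0.12 log units; within the scatter) so none beyond the scatter is expected, with the direction left open. Compound 3 is estimated at 7000 nM (range 2500 nM to 20000 nM).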

Compound 3, half-maximal inhibitory concentration: > 16000 nM
Compound 3: only a limit was reported; the forecaster's own chance of this, stated with the estimate: 10%; at least 2.2-fold (0.35 log units) between middle value and limit.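

The earlier compounds shown here both carry the 4-(trifluoromethyl)phenyl group, so they said nothing about this position. In this assay, hydrogen in place of trifluoromethyl gives an at least 1.7-fold higher number from compound 1 to compound 3 (0.24 log units; that floor lies within the scatter), so this change brings no lower number, although that floor does not separate the two compounds. Compound 3 has a limit rather than a number: the limit of > 16000 nM in this assay, at which 1 of the 3 values shown sits.

Going by these compounds, how far compound 3 lies past its limit stays open, and with it whether trifluoromethyl matters here beyond the scatter. So does how a chlorine atom, a methoxy group or an amine at this carbon would read.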